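Dichlorophenyl Swap on the Shared Core

The compounds below may be only part of what the source reports. "The series", "measured", "known", "first", "only" and "open" are said of these compounds alone.

Compound 1, `O=C(Nc1cccc(F)c1)Nc1cc2ncncc2cc1OCc1cccc(Cl)c1`: 3700 nM
Compound 2, `O=C(Nc1ccccc1F)Nc1cc2ncncc2cc1OCc1ccccc1F`: 4200 nM
Compound 3, `O=C(Nc1cccc(Cl)c1)Nc1cc2ncncc2cc1OCc1ccccc1`: 5700 nM

In a functional assay on GBM1 cells (Homo sapiens) for antiproliferative activity, read by WST assay, with a stated time of 72 h (on this read-out lower numbers stand for stronger inhibition and higher numbers for weaker inhibition), the three measured compounds give numbers that lie close together. Compound 2 stands second highest of the three, with compound 1 nearest to it and compound 3 furthest from it, and both gaps fall within the scatter, so no order among the three can be claimed from these numbers. Compound 4, `O=C(Nc1ccc(Cl)c(Cl)c1)Nc1cc2ncncc2cc1OCc1ccccc1F`, has not yet been measured in this assay. It differs from compound 2 in one place: 3,4-dichlorophenyl in place of 2-fluorophenyl on an amide-type nitrogen. Among the measured compounds shown here, no pair of the measured compounds differs in a single place, so no measured step tells how much a change at that amide-type nitrogen moves the number. The three measured compounds carry different groups at that nitrogen and still give numbers within the scatter of one another, which suggests that the move from compound 2 to compound 4 is expected to stay small. The step of a 1.4-fold lower number from compound 2 to compound 4 (0.15 log units; within the scatter) is the estimate, with a slight lean toward a lower number that does not exceed the scatter. Compound 4 is therefore expected to give about 3000 nM, with a range from 1000 nM to 9000 nM.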

Compound 4, half-maximal inhibitory concentration: 4100 nM
The estimate for compound 4 lay 1.4-fold (0.14 log units) below the measured number, and the stated range covers the measured number.
By their numbers in this assay, from the lowest: compounds 1, 4, 2 and 3 (each within the scatter of the next).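

In this assay, the exchange of 2-fluorophenyl for 3,4-dichlorophenyl on an amide-type nitrogen gives a 1.0-fold lower number from compound 2 to compound 4 (0.01 log units; within the scatter). Among the compounds shown here, this is the first reading of a change at this position alone, as the earlier compounds differed from one another in more than one place, and it shows that this position accepts the 3,4-dichlorophenyl group in place of the 2-fluorophenyl group with no change in the number beyond the scatter. No measurement among the compounds shown accounts for this result.

Both groups in this step are six-membered aromatic rings of carbon only, so the compounds shown leave open whether the number would hold with a group of another kind on this nitrogen, such as a piperidine, a carboxylic acid-bearing phenyl or a longer alkyl chain. They also leave open whether the same exchange would give a similar step with a different group at the other substituted positions of the shared core.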